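Dropping the isopropyl: compound 2 to compound 4

The compounds below may be only part of what the source reports. "The series", "measured", "known", "first", "only" and "open" are said of these compounds alone.

Measured so far:
compound 1 `COc1ccccc1/C=C/C(=O)c1ccc(OCC(=O)N[C@H]2CCOC2=O)cc1` gives 10100 nM
compound 2 `CC(C)c1ccc(NCC(=O)N[C@H]2CCOC2=O)cc1` gives only a limit, > 64000 nM
compound 3 `O=C(CNc1ccc(Cl)cc1Cl)N[C@H]1CCOC1=O` gives only a limit, > 64000 nM

Among the compounds with values here, in a functional assay on DU-145 cells (Homo sapiens) for antiproliferative activity, read by MTT assay, with a stated time of 72 h (a lower number here means a stronger inhibitor, a higher number a weaker inhibitor), compound 1 is the one compound with a number. Compound 2 reaches only the limit of the assay. Compound 3 likewise stops at a limit. Within the data shown here, compound 2 therefore stands at the limit of > 64000 nM in this assay, at which 2 of the 3 values shown sit, and no step between two measured compounds is available.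

Compound 4 `O=C(CNc1ccccc1)N[C@H]1CCOC1=O` differs from compound 2 by hydrogen in place of isopropyl on an aromatic carbon. With compound 2 at a limit, the step expected from it in this assay is a number no higher from compound 2 to compound 4 (the limit leaves the size open), which is no change beyond the usual scatter; the estimate rests on compound 2 and its limit value > 64000 nM. Compound 4 is expected to give 64000 nM, within 25000 nM to 150000 nM, and most likely again only a limit.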

Compound 4, half-maximal inhibitory concentration: > 64000 nM
Compound 4 was reported as a limit; the forecaster's own chance of this, stated with the estimate: 80%; the middle value lies on the limit itself.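

In this assay, within the data shown here, compound 2 and compound 4 each stop at a limit, and no step between them can be read. The compounds shown leave open whether hydrogen in place of isopropyl changes antiproliferative activity at all.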